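The source may report more compounds than this note shows. Statements on the series, on what has been measured and on what is new or still open speak of the compounds shown alone.

Measured so far:
compound 1 `Nc1nc(Cl)c2ncn(Cc3ccccc3CCl)c2n1` 5130 nM
compound 2 `ClCc1ccccc1Cn1cnc2ncnc(Cl)c21` 1650 nM

In a functional assay on MOLT-4 cells (Homo sapiens) for cytotoxicity, read by sulforhodamine B assay, with a stated time of 48 h (on this read-out lower numbers stand for stronger inhibition of growth and higher numbers for weaker inhibition of growth), compound 1 gives 5130 nM and stands highest of the two numbers; compound 2 gives 1650 nM, a gap beyond the scatter. Compound 3 `ClCc1ccccc1Cn1cnc2c(Cl)ncnc21` has not been measured. It differs from compound 1 by hydrogen in place of amino on an aromatic carbon. For the measured compounds named here, no measured pair shows this change, so its size is unknown; only compound 2, which also lacks the amino group and gives 1650 nM, hints at the direction. A moderate step downward from compound 1, a 2.1-fold lower number from compound 1 to compound 3 (0.31 log units; beyond the scatter), is expected. Compound 3 is estimated at 2500 nM, range 800 nM to 7500 nM.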

Compound 3, concentration for 50% growth inhibition: 1580 nM
Estimate against measurement, compound 3: 1.6-fold (0.20 log units) above; the measured number falls inside the stated range.
By their numbers in this assay, from the lowest: compounds 3 and 2 (each within the scatter of the next); then compound 1.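

Under this assay replacing amino with hydrogen on the aromatic carbon between two ring nitrogen atoms gives a 3.2-fold lower number from compound 1 to compound 3 (0.51 log units; beyond the scatter), so this change now has a measured size, and the amino group is not required for growth inhibition in this pair. Compound 3 and compound 2 lie within the scatter of each other. No measurement at hand accounts for the step.

On these data alone, whether a methyl group, a hydroxyl group or a methylamino group on this carbon would read like hydrogen or like amino remains open.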